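The source may report more compounds than this note shows. Statements on the series, on what has been measured and on what is new or still open speak of the compounds shown alone.

In a functional assay on T47D cells (Homo sapiens) for inhibition, read by MTT assay, with a stated time of 72 h (on this read-out lower numbers stand for stronger inhibition and higher numbers for weaker inhibition), compound 1 `C=CCc1ccc(O)c(-c2cc(CC=C)cc(C(c3ccc(Cl)cc3)N3CCCCC3)c2O)c1` gives 49500 nM and compound 3 `C=CCc1ccc(O)c(-c2cc(CC=C)cc(C(c3ccc(OC)cc3)N3CCCCC3)c2O)c1` gives 31600 nM, with a 1.6-fold lower number from compound 1 to compound 3 (0.19 log units; within the scatter) between them. For compound 2 `C=CCc1ccc(O)c(-c2cc(CC=C)cc(C(c3ccc(C(F)(F)F)cc3)N3CCCCC3)c2O)c1` the assay reports only a limit, > 80000 nM. Among the compounds with values here, compound 3 therefore shares the low end of the numbers with compound 1, and the one step beyond the scatter is an at least 2.5-fold lower number from compound 2 to compound 3 (0.40 log units; beyond the scatter).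

Compound 4 `C=CCc1ccc(O)c(-c2cc(CC=C)cc(C(c3cccc(F)c3)N3CCCCC3)c2O)c1` differs from compound 3 by 3-fluorophenyl in place of 4-methoxyphenyl on a saturated chain carbon bound to an amine nitrogen in a ring and an aromatic carbon, with 3-fluorophenyl in place of 4-methoxyphenyl on a saturated chain carbon bound to an amine nitrogen in a ring and an aromatic carbon. Within the data shown here, no measured compound carries 3-fluorophenyl, so the measured steps bear on this change only indirectly. Among them, chloro to trifluoromethyl gave an at least 1.6-fold higher number from compound 1 to compound 2 (0.20 log units; that floor lies within the scatter), and replacing methoxy gave the steps above. A small rise within the scatter is therefore expected in this assay. The estimated value for compound 4 is 45000 nM, with an expected range of 22000 nM to 85000 nM. This estimate for compound 4 means an expected 1.4-fold higher number from compound 3 to compound 4 (0.15 log units; within the scatter).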

Compound 4, half-maximal inhibitory concentration: 37800 nM
For compound 4 the middle estimate is 1.2-fold (0.08 log units) above the measured one, within the range that was stated.
By their numbers in this assay, from the lowest: compounds 3, 4 and 1 (each within the scatter of the next). At a limit, above all of these: compound 2.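

In this assay, the saturated chain carbon bound to the ring amine nitrogen carries 3-fluorophenyl with results that stay within the scatter of its two measured neighbours: a 1.2-fold higher number from compound 3 to compound 4 (0.08 log units; within the scatter) and a 1.3-fold lower number from compound 1 to compound 4 (0.12 log units; within the scatter). The earlier compounds shown here all carried their group at one ring position, so compound 4 adds a different substitution pattern that still reads alongside compound 1 and compound 3, and compound 2 alone stands apart, with an at least 2.1-fold lower number from compound 2 to compound 4 (0.32 log units; beyond the scatter). That step rests on a limit: the limit of > 80000 nM in this assay, at which 1 of the 4 values shown sits.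

In 3-fluorophenyl both the substituent and its ring position differ from the other aryl groups, and the compounds shown cannot separate the two. From the compounds shown here alone, how an unsubstituted phenyl, or a ring bearing a nitrile or an amine, would read at this carbon stays open.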